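A few compounds are considered here, and "the series" means these few. Any claim that something is new, unique, unknown or untested is made for them only; others in the source may bear on it.

Measured in an in vivo ADME assay on the whole organism (strain 129/SvEvBrd x C57BL/6) for pharmacokinetics, with Mus musculus as the target; a lower number here means that a smaller share of the oral dose reaches the circulation, a higher number that a larger share of the oral dose reaches the circulation:
- Compound 1 `CC(=O)c1nc([C@@H](O)[C@H](O)[C@H](O)CO)cn1C`: 33.6%
- Compound 2 `CC(=O)c1nc([C@@H](O)[C@H](O)[C@H](O)CO)c(C)[nH]1`: 11%

Compound 2, at 11%, has the lower of the two numbers, and compound 1, at 33.6%, lies higher by more than the usual scatter. Compound 3 `CCc1[nH]c(C(C)=O)nc1[C@@H](O)[C@H](O)[C@H](O)CO` differs from compound 2 in one place: methyl in place of hydrogen on a saturated chain carbon bound to an aromatic carbon. This puts methyl in place of hydrogen on a saturated chain carbon bound to an aromatic carbon, turning methyl into ethyl. Going by the values given here, no measured pair shows the effect of such a change, so no step beyond the scatter is expected in this assay. The expected step is a number 3 percentage points higher from compound 2 to compound 3 (within the scatter). For compound 3 the estimate is 14%, with an expected range from 5% to 30%.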

Compound 3, oral bioavailability: 17.1%
Beside the measured number, compound 3's estimate is 3.1 percentage points below it; the measured number falls inside the stated range.
By their numbers in this assay, from the lowest: compounds 2 and 3 (each within the scatter of the next); then compound 1.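

In this assay, going by these compounds alone, this is the first pair to isolate methyl in place of hydrogen on a saturated chain carbon bound to an aromatic carbon, turning methyl into ethyl, and it gives a number 6.1 percentage points higher from compound 2 to compound 3 (within the scatter). At this place, then, one added carbon leaves the reading within the scatter. No supporting measurement bears on this result. As far as these compounds go, a longer chain such as propyl remains open, as does an amine or a carboxylic acid at this place. Whether any of these would move the number beyond the scatter cannot be told from the compounds shown.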